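The source may report more compounds than this note shows. Statements on the series, on what has been measured and on what is new or still open speak of the compounds shown alone.

The study surveys three measured compounds in a functional assay on cells (Platelet, Oryctolagus cuniculus) for inhibition, read by turbidimetry, with a stated time of 3 min, tested at 100 ug/mL; on this read-out lower numbers stand for a stronger effect and higher numbers for a weaker effect at the one concentration tested. Compound 1 `CCCCCCC(=O)CC/C=C/C=C/C(=O)NCC(C)C` gives 0%, compound 2 `CC/C=C/C/C=C\CC/C=C/C=C/C(=O)NCC(C)(C)O` gives 38.4%, and compound 3 `COc1ccc(-c2oc3c(OC)c(OC)cc(O)c3c(=O)c2O)cc1` gives 78.6%. Compound 2 therefore holds the second-highest reading of the three: its nearest neighbour is compound 1, which sits beyond the scatter below it, while compound 3 lies beyond the scatter above it. The next compound, compound 4 `CCCCCCCCC/C=C/C=C/C(=O)NCC(C)(C)O`, has not yet been tested in this assay. It differs from compound 2 in one place: heptyl in place of hepta-1,4-dien-1-yl on a saturated chain carbon, two bonds along the chain from a double-bonded chain carbon. Among the measured compounds shown here, no step between measured compounds matches this change. A modest move downward is expected, a number 13.4 percentage points lower from compound 2 to compound 4 (beyond the scatter), leaning on compound 1 with its saturated chain and 0%. Compound 4 is estimated at 25%, within a range from 5% to 55%.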

Compound 4, a percentage reported as activity, at one concentration (the size of the read-out at that concentration, not a potency): 6.7%
Compound 4: middle estimate off by 18.3 percentage points, on the high side; measured number inside the range.
By their numbers in this assay, from the lowest: compounds 1 and 4 (each within the scatter of the next); then compound 2; then compound 3.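

Replacing hepta-1,4-dien-1-yl with heptyl on this saturated chain carbon gives a number 31.7 percentage points lower from compound 2 to compound 4 (beyond the scatter) in this assay and moves the read-out towards a stronger effect. The group keeps the same heavy-atom count, so this large step goes with the loss of its two double bonds alone. No measured evidence explains the step.

The compounds shown leave open whether a chain keeping only one of the two double bonds would read nearer compound 2 or compound 4. They also leave open how a longer chain or a terminal carboxylic acid would read at this position.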